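This account rests on a few compounds, and the source may have more. Where it says the series, first, only, none or still open, it means among the compounds named here.

Measured compounds: compound 1 `CCCCc1ccc(CN(c2ccccc2CCCC(=O)O)S(C)(=O)=O)cc1`, compound 2 `CC(C)(C)c1ccc(CN(Cc2cccc(OCC(=O)O)c2)S(C)(=O)=O)cc1`, and compound 3 `Cn1ccnc1CS(=O)(=O)N(Cc1ccc(C(C)(C)C)cc1)Cc1cccc(OCC(=O)O)c1`.

In an assay on HEK293 cells for inhibition of prostaglandin E2 receptor EP4 subtype (Rattus norvegicus) (on this read-out lower numbers stand for stronger inhibition and higher numbers for weaker inhibition), compound 1 gives only a limit, > 3200 nM. Compound 2 likewise gives only a limit, > 3200 nM. Compound 3 also gives only a limit, > 3200 nM. Compound 2 thus stands at a limit, not a number, so its place among the three cannot be read. Among the measured compounds shown here, the one step between neighbours, a step that the two limits leave unreadable from compound 2 to compound 3, stays unreadable since (the limit of > 3200 nM in this assay, at which 3 of the 3 values shown sit). Compound 4, `CC(C)(C)c1ccc(CN(Cc2cccc(CCC(=O)O)c2)S(C)(=O)=O)cc1`, differs from compound 2 by 2-carboxyethyl in place of carboxymethoxy on an aromatic carbon. For the measured compounds named here, no measured step bears on this change, and the values of compound 1 and compound 2 are both limits. Compound 4 is therefore expected to stay near the limit in this assay, estimated at 5000 nM, between 1500 nM and 20000 nM. The step this estimate implies is expected to be a step that the limit leaves unreadable from compound 2 to compound 4.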

Compound 4, half-maximal inhibitory concentration: > 3200 nM
Compound 4 ended at the assay's limit (the forecaster's own chance of this, stated with the estimate: 70%); the middle value lies beyond the limit too.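

Compound 2 and compound 4 both stand at a limit, so no step between them can be read: the limit of > 3200 nM in this assay, at which 4 of the 4 values shown sit.

The compounds shown leave open whether swapping carboxymethoxy for 2-carboxyethyl changes anything in this assay, and which structure would give a true number there.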